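Urea aryl swap on a shared core: compound 4 expected

This account rests on a few compounds, and the source may have more. Where it says the series, first, only, none or still open, it means among the compounds named here.

Three compounds share one core and differ only in the group on the carbonyl carbon. Compound 1 `O=C(NC1CCN(c2ncnc3[nH]ncc23)CC1)c1ccc(Br)cc1` gives 16400 nM in an assay on isolated protein for inhibition of serine/threonine-protein kinase PAK 1 (Homo sapiens), read by ADP-Glo, with a stated time of 40 min; a lower number here means a stronger inhibitor, a higher number a weaker inhibitor. Compound 2 `O=C(NC1CCN(c2ncnc3[nH]ncc23)CC1)c1cccc(Cl)c1Cl` gives 4170 nM in this assay, and compound 3 `Cc1cccc(C)c1NC(=O)NC1CCN(c2ncnc3[nH]ncc23)CC1` gives 2160 nM. The steps are a 3.9-fold lower number from compound 1 to compound 2 (0.59 log units; beyond the scatter) and a 7.6-fold lower number from compound 1 to compound 3 (0.88 log units; beyond the scatter), while a 1.9-fold lower number from compound 2 to compound 3 (0.29 log units; within the scatter) stays within the scatter; compound 3 therefore holds the lowest number of the three, though its separation from compound 2 is not beyond the scatter.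

Compound 4 `O=C(Nc1cccc(Cl)c1)NC1CCN(c2ncnc3[nH]ncc23)CC1` carries the change (3-chlorophenyl in place of 2,6-dimethylphenyl on an amide-type nitrogen). For the measured compounds named here, no measured step bears directly on exchanging one aryl group for another on a urea nitrogen; the nearest guide is a 3.9-fold lower number from compound 1 to compound 2 (0.59 log units; beyond the scatter), an aryl exchange on an amide carbonyl, which was modest, and a 1.9-fold lower number from compound 2 to compound 3 (0.29 log units; within the scatter), which was within the scatter. The step is therefore expected to be small, with no confident direction: a 1.2-fold higher number from compound 3 to compound 4 (0.08 log units; within the scatter). Compound 4 is expected to give about 2600 nM, within 800 nM to 8500 nM.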

Compound 4, half-maximal inhibitory concentration: 1240 nM
For compound 4 the middle estimate is 2.1-fold (0.32 log units) above the measured one, and the stated range covers the measured number.
By their numbers in this assay, from the lowest: compounds 4, 3 and 2 (each within the scatter of the next, the first and the last beyond it); then compound 1.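

In this assay, 3-chlorophenyl in place of 2,6-dimethylphenyl on an amide-type nitrogen gives a 1.7-fold lower number from compound 3 to compound 4 (0.24 log units; within the scatter), so this exchange does not separate the two urea compounds. Against the amides, (3-chlorophenyl)amino on the carbonyl carbon gives a 3.4-fold lower number from compound 2 to compound 4 (0.53 log units; beyond the scatter) and a 13-fold lower number from compound 1 to compound 4 (1.12 log units; beyond the scatter), whereas compound 3 did not clear the scatter against compound 2, with a 1.9-fold lower number from compound 2 to compound 3 (0.29 log units; within the scatter); the urea advantage over both amides therefore holds for compound 4, while compound 3 goes against it in the comparison with compound 2. No measured property offered here accounts for these steps.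

Going by these compounds, what an amide carrying 3-chlorophenyl directly on the carbonyl carbon would give remains open, and with it the contribution of the urea nitrogen alone. Also open, on these data alone, is how a urea aryl ring bearing an amine or a carboxylic acid would behave.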